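The source may hold more compounds than are shown below. What is called first, only, known or untested is meant among the compounds shown, and "the series" means these compounds.

Working notes on the series. In a functional assay on HT-29 cells (Homo sapiens) for cytotoxicity, read by sulforhodamine B assay (a lower number here means a stronger inhibitor, a higher number a weaker inhibitor), compound 1 `C=C1[C@@H](OC(C)=O)C[C@@H]2[C@](C)(CO[Si](C)(C)C(C)(C)C)[C@H](OC(C)=O)CC[C@@]2(C)[C@@H]1C[C@@H](Nc1ccc(OC)c(OC)c1)C1=CCOC1=O` reads 5330 nM and compound 3 `C=C1[C@@H](OC(C)=O)C[C@@H]2[C@](C)(COC=O)[C@H](OC(C)=O)CC[C@@]2(C)[C@@H]1C/C=C1/C(=O)OC[C@H]1OC(C)=O` reads 8290 nM while compound 2 `C=C1[C@@H](OC(C)=O)C[C@@H]2[C@](C)(COC=O)[C@H](OC(C)=O)CC[C@@]2(C)[C@@H]1C[C@@H](Nc1cccc(F)c1)C1=CCOC1=O` reads 9410 nM and so lies within the scatter of both. The next compound to read is compound 4 `C=C1[C@@H](OC(C)=O)C[C@@H]2[C@](C)(COC=O)[C@H](OC(C)=O)CC[C@@]2(C)[C@@H]1C[C@@H](Nc1ccc(F)cc1)C1=CCOC1=O` and its difference from compound 2 is 4-fluorophenyl in place of 3-fluorophenyl on an amine nitrogen which amounts to 4-fluorophenyl in place of 3-fluorophenyl on an amine nitrogen. Among the measured compounds shown here, no two measured compounds differ in one place only, so the series offers no direct precedent for this change. No step beyond the scatter is expected in this assay in either direction. The estimated step of a 1.1-fold lower number from compound 2 to compound 4 (0.04 log units; within the scatter) is expected to stay within the scatter. Compound 4 is expected at an estimated 8500 nM (range 4000 nM to 18000 nM).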

Compound 4, half-maximal inhibitory concentration: 20500 nM
Compound 4: the middle estimate sits 2.4-fold (0.38 log units) below what was measured; measured number above the stated range.
By their numbers in this assay, from the lowest: compounds 1, 3 and 2 (each within the scatter of the next); then compound 4.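

In this assay, the series gives its first step between compounds that differ in one place: 4-fluorophenyl in place of 3-fluorophenyl on an amine nitrogen gives a 2.2-fold higher number from compound 2 to compound 4 (0.34 log units; beyond the scatter). The two compounds have the same atoms, so this modest step shows that the read-out at this position responds to the placement of the fluorine alone. Nothing available explains the step.

Open, going by these compounds, is whether an unsubstituted phenyl on the same nitrogen would read closer to compound 2 or to compound 4. Also open, on these data alone, is whether 4-chlorophenyl would read like 4-fluorophenyl.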